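The compounds below may be only part of what the source reports. "The series", "measured", "known", "first", "only" and "open" are said of these compounds alone.

Compounds measured so far in an ADME assay on microsomes from liver (Mus musculus) for metabolic stability, read by LC-MS, with a stated time of 30 min, tested at 1 uM; on this read-out lower numbers stand for a less stable compound and higher numbers for a more stable compound:
compound 1 `O=C(NCc1ccc(S(=O)(=O)c2ccccc2)cc1)c1nc2cnccc2[nH]1`: 7.3%
compound 2 `O=C(NCc1ccc(S(=O)(=O)c2ccccc2)cc1)c1cn2ccnc2cn1`: 13%
compound 3 `O=C(NCc1ccc(S(=O)(=O)c2ccccc2)cc1)c1ccc2nccn2c1`: 18%

Compound 3 stands highest of the three numbers in this assay, though its margin is thin: a number 5 percentage points higher from compound 2 to compound 3 (within the scatter), and a number 10.7 percentage points higher from compound 1 to compound 3 (beyond the scatter).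

Compound 4 `O=C(NCc1ccc(S(=O)(=O)c2cccc(C(F)(F)F)c2)cc1)c1ccc2nccn2c1` differs from compound 3 by trifluoromethyl in place of hydrogen on an aromatic carbon. Going by the values given here, all three measured steps, a number 5.7 percentage points higher from compound 1 to compound 2 (within the scatter), a number 10.7 percentage points higher from compound 1 to compound 3 (beyond the scatter) and a number 5 percentage points higher from compound 2 to compound 3 (within the scatter), act on the carbonyl carbon and were small; none touches the ring where the new group enters, so no measured step bears on this change directly. No step beyond the scatter is therefore expected for compound 4, whose value in this assay is estimated at 20%, within 8% to 38%, an expected step of a number 2 percentage points higher from compound 3 to compound 4 (within the scatter).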

Compound 4, percent of the compound remaining: 17%
For compound 4 the middle estimate is 3 percentage points above the measured one, and the stated range covers the measured number.
By their numbers in this assay, from the lowest: compounds 1, 2, 4 and 3 (each within the scatter of the next, the first and the last beyond it).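

The change from phenyl to 3-(trifluoromethyl)phenyl is the first shown away from the group on the carbonyl carbon, and in this assay it gives a number 1 percentage points lower from compound 3 to compound 4 (within the scatter). This ring therefore accepts trifluoromethyl at this place without a step beyond the scatter. No measurement available here accounts for this result.

As far as these compounds go, whether an amine or a carboxylic acid at the same place would shift the number remains open. So does whether phenyl to 3-(trifluoromethyl)phenyl behaves alike with the cores of compound 1 and compound 2.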